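From methyl to 1-methoxyethyl: a step in antiproliferative activity

The source may hold more compounds than are shown below. What is called first, only, known or untested is meant among the compounds shown, and "the series" means these compounds.

Measured in a functional assay on OCI-Ly3 cells (Homo sapiens) for antiproliferative activity; a lower number here means that less compound is needed, a higher number that more compound is needed for the effect:
Compound 1 `O=C(Nc1cnc(-n2nccn2)c(Cl)c1)Nc1cncc2ccccc12`: > 20000 nM (a limit of the assay)
Compound 2 `Cc1c(NC(=O)Nc2cnc(-n3nccn3)c(Cl)c2)cnc2ccccc12`: 7170 nM
Compound 3 `O=C(Nc1cnc(-n2nccn2)c(Cl)c1)Nc1cnc2cc(F)ccc2c1C1CC1`: 900 nM

The result for compound 1 is a limit and not a number. Of the two numbers, compound 2 at 7170 nM is the higher, and the gap down to compound 3 at 900 nM lies beyond the scatter. Compound 4 `COC(C)c1c(NC(=O)Nc2cnc(-n3nccn3)c(Cl)c2)cnc2ccccc12` carries 1-methoxyethyl in place of methyl on an aromatic carbon, opposite the ring nitrogen (1-methoxyethyl in place of methyl on an aromatic carbon). Within the data shown here, no measured step isolates this change, so the expectation leans on compound 3 at 900 nM, the lowest number so far. The expected step is a 4.8-fold lower number from compound 2 to compound 4 (0.68 log units; beyond the scatter), towards a lower number in this assay. Compound 4 is estimated at 1500 nM, with an expected range of 300 nM to 7000 nM.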

Compound 4, half-maximal effective concentration: 620 nM
Beside the measured number, compound 4's estimate is 2.4-fold (0.38 log units) above it, within the range that was stated.
By their numbers in this assay, from the lowest: compounds 4 and 3 (each within the scatter of the next); then compound 2. At a limit, above all of these: compound 1.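

Among these compounds, replacing methyl with 1-methoxyethyl on the aromatic carbon opposite the ring nitrogen gives a 12-fold lower number from compound 2 to compound 4 (1.06 log units; beyond the scatter) in this assay and provides the first measured step at this position. It shows that this position tolerates the larger chain, which adds an oxygen, and that less compound is then needed for the effect. Nothing measured here accounts for the size of this step. Going by these compounds, whether the oxygen or the added carbons matter remains open, and ethyl, isopropyl, methoxymethyl or an amine at this position could separate the two.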